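The source may hold more compounds than are shown below. What is called first, only, known or untested is meant among the compounds shown, and "the series" means these compounds.

In a functional assay on CWR22R cells (Homo sapiens) for antiproliferative activity, read by CCK-8 assay, with a stated time of 6 days (a lower number here means a stronger inhibitor, a higher number a weaker inhibitor), compound 1 `N#Cc1ccc(N2CCc3cc(-c4cccnc4)ccc32)cc1C(F)(F)F` reads "not determined" (no result reported), and compound 2 `N#Cc1ccc(N2CCc3cc(-c4cnc5ccccc5c4)ccc32)cc1C(F)(F)F` reads "not determined" (no result reported). Compound 3 `CCN(c1ccc(C#N)c(Cl)c1)c1cc(-c2ccco2)ccc1C` gives > 30000 nM, which is a limit of the assay and not a number. Compound 4 `CCN(c1ccc(C#N)c(Cl)c1)c1cc(-c2ccc(F)nc2)ccc1C` carries 6-fluoropyridin-3-yl in place of furan-2-yl on an aromatic carbon, meta to a large group and para to a methyl group (6-fluoropyridin-3-yl in place of furan-2-yl on an aromatic carbon). For the measured compounds named here, no measured pair shows what size of step to expect in this assay, so only a modest gain in potency is expected, and another result at the limit remains quite possible. The expected change is an at least 2.5-fold lower number from compound 3 to compound 4 (0.39 log units; beyond the scatter). For compound 4 the estimated value is 12000 nM, with an expected range of 3000 nM to 30000 nM.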

Compound 4, half-maximal inhibitory concentration: 16500 nM
Beside the measured number, compound 4's estimate is 1.4-fold (0.14 log units) below it, and the stated range covers the measured number.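

In this assay, for the compounds shown here, 6-fluoropyridin-3-yl in place of furan-2-yl on this aromatic carbon, para to a methyl group, gives the first step at this position: an at least 1.8-fold lower number from compound 3 to compound 4 (0.25 log units; that floor lies within the scatter). That step is only a floor, and its true size stays unknown, since compound 3 sits at a limit of the assay and not at a number: the limit of > 30000 nM in this assay, at which 1 of the 4 values shown sits.

Going by these compounds, what the fluorine and the ring nitrogen each contribute stays open. Also open, on these data alone, is how an amine or a methoxy group in place of the fluorine would read on the core of compound 4.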